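The source may hold more compounds than are shown below. What is called first, only, known or untested is meant among the compounds shown, and "the series" means these compounds.

Working notes on the series.

Compound 1 `COc1cc(C)nc2n/c(=N/C(=O)c3c(-c4ccc(Cl)cc4Cl)noc3C)sn12` stands second highest of the three numbers measured in a functional assay on the whole organism for inhibition, with Digitaria ciliaris as the target, with a stated time of 72 h, tested at 10 mg/L; on this read-out lower numbers stand for less inhibition of growth and higher numbers for more inhibition of growth at the one concentration tested; compound 1 gives 50.3%. Its nearest neighbour is compound 3 `COc1cc(OC)n2s/c(=N\C(=O)c3c(-c4ccc(Cl)cc4Cl)noc3C)nc2n1`, which gives 53.8% in this assay, and the furthest is compound 2 `CSc1cc(C)nc(NC(=S)NC(=O)c2c(-c3ccc(Cl)cc3Cl)noc2C)n1`, which gives 26.7% in this assay. For the measured compounds named here, the one step measured in one place, a number 3.5 percentage points higher from compound 1 to compound 3 (within the scatter), swaps methoxy for methyl on an aromatic carbon and lies within the scatter.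

Compound 4 `CSc1cc(C)nc2n/c(=N/C(=O)c3c(-c4ccc(Cl)cc4Cl)noc3C)sn12` differs from compound 1 by methylsulfanyl in place of methoxy on an aromatic carbon. Going by the values given here, no measured step changes a methoxy to a methylsulfanyl on this core, so nothing bears directly on the change. Compound 2 carries a methylsulfanyl but differs from compound 1 in more than one place, so its value is not a guide to this step alone. Among the compounds with values here, the only one-place step on the core, a number 3.5 percentage points higher from compound 1 to compound 3 (within the scatter), was within the scatter, so a step of the expected size a number 4.3 percentage points lower from compound 1 to compound 4 (within the scatter), that is none beyond the scatter, is the estimate. Compound 4 is thus expected to give 46% in this assay, within 26% to 66%.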

Compound 4, percent growth inhibition at one concentration: 26.8%
The estimate for compound 4 lay 19.2 percentage points above the measured number; the measured number falls inside the stated range.
By their numbers in this assay, from the lowest: compounds 2 and 4 (each within the scatter of the next); then compounds 1 and 3 (each within the scatter of the next).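

In this assay, for the compounds shown here, the position bearing the methoxy on the core of compound 1 is sensitive to this exchange: a number 23.5 percentage points lower from compound 1 to compound 4 (beyond the scatter), so methylsulfanyl in place of methoxy is the first one-place change to go beyond the scatter. The earlier one-place step, which replaces the methyl rather than this methoxy, gave a number 3.5 percentage points higher from compound 1 to compound 3 (within the scatter) and stayed within the scatter, so tolerance of that change does not carry over to this one. No measurement at hand accounts for the loss of inhibition of growth.

On these data alone, it remains open whether an amine, chlorine or a longer chain such as ethylsulfanyl at this carbon would keep the number of compound 1 or fall with compound 4. Also open, as far as these compounds go, is whether methylsulfanyl would cost as much on the core of compound 3.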